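Swapping the vinyl arm for a dimethoxyphenyl arm

This account rests on a few compounds, and the source may have more. Where it says the series, first, only, none or still open, it means among the compounds named here.

Measured compounds:
Compound 1 `CCN1C(=O)C(=O)c2cc(-c3ccc(OC)cc3)ccc21`: 2200 nM
Compound 2 `C=CCN1C(=O)C(=O)c2cc(-c3ccc(OC)cc3)ccc21`: 390 nM
Compound 3 `COc1ccc(-c2ccc3c(c2)C(=O)C(=O)N3Cc2cccc(OC)c2)cc1`: 680 nM

All three share one core and differ only in the group on the saturated chain carbon bound to the amide-type nitrogen in the ring. In a functional assay on K562 cells (Homo sapiens) for antiproliferative activity, read by MTT assay, with a stated time of 48 h (a lower number here means a stronger inhibitor, a higher number a weaker inhibitor), compound 2 gives the lowest number of the three; compound 3 sits within the scatter of it, while compound 1 lies a 5.6-fold lower number from compound 1 to compound 2 (0.75 log units; beyond the scatter) away. Compound 4 `COc1ccc(-c2ccc3c(c2)C(=O)C(=O)N3Cc2ccc(OC)c(OC)c2)cc1` is not yet measured. The change is 3,4-dimethoxyphenyl in place of vinyl on a saturated chain carbon bound to an amide-type nitrogen in a ring. The nearest measured step, a 1.7-fold higher number from compound 2 to compound 3 (0.24 log units; within the scatter), put an aryl group in place of vinyl at the same place with no shift beyond the scatter, and a 3.2-fold lower number from compound 1 to compound 3 (0.51 log units; beyond the scatter) shows an aryl group there is at least as good as methyl. As far as these compounds go, a second methoxy on the ring is untested. Compound 4 is therefore expected to land close to compound 2, with a step of a 1.5-fold higher number from compound 2 to compound 4 (0.19 log units; within the scatter), estimated at 600 nM (range 250 nM to 1500 nM).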

Compound 4, half-maximal inhibitory concentration: 60 nM
Estimate against measurement, compound 4: 10-fold (1.00 log units) above; the measured number lies below the stated range.
By their numbers in this assay, from the lowest: compound 4; then compounds 2 and 3 (each within the scatter of the next); then compound 1.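

In this assay, among these compounds, the group on this chain carbon proves far more sensitive than the earlier compounds showed: methoxy in place of hydrogen on an aromatic carbon brings an 11-fold lower number from compound 3 to compound 4 (1.05 log units; beyond the scatter) and so separates two closely related aryl arms. The 3,4-dimethoxyphenyl arm also stands clear of vinyl, with a 6.5-fold lower number from compound 2 to compound 4 (0.81 log units; beyond the scatter) and of methyl, with a 37-fold lower number from compound 1 to compound 4 (1.56 log units; beyond the scatter) in that comparison. Nothing available explains this gain. Still open, as far as these compounds go, is whether the gain needs both methoxy groups, and whether other groups on that ring, such as a hydroxyl or an amine, would do the same.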